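Benzothiophene Amide in Place of the Phenylbutanoyl Chain

The source may hold more compounds than are shown below. What is called first, only, known or untested is meant among the compounds shown, and "the series" means these compounds.

Compound 2 `CC(C)[C@@H](NC(=O)CCCc1ccccc1)C(=O)N1CCC(c2ccc(Cl)cc2)CC1` is one of two compounds with a result in an assay on THP-1 cells for displacement of a labelled ligand from C-C chemokine receptor type 1 (Homo sapiens); on this read-out higher numbers stand for weaker inhibition and lower numbers for stronger inhibition. In this assay compound 2 gives 95 nM, the higher of the two numbers. Among the measured compounds shown here, its closest relative, compound 1 `CC(C)CC(=O)N[C@@H](C(=O)N1CCC(c2ccc(Cl)cc2)CC1)C(C)C`, gives 32 nM in this assay, and the single step between them, a 3.0-fold higher number from compound 1 to compound 2 (0.47 log units; beyond the scatter), is the only measured change so far. Compound 3 `CC(C)[C@@H](NC(=O)c1cc2ccccc2s1)C(=O)N1CCC(c2ccc(Cl)cc2)CC1` has not been measured. It differs from compound 2 in one place: 1-benzothiophen-2-yl in place of 3-phenylpropyl on a carbonyl carbon. For the measured compounds named here, the step from compound 1 to compound 2 concerns the same acyl part of the molecule, but it lengthened a saturated chain, whereas the change to compound 3 removes the chain altogether and places an aromatic bicycle directly on the carbonyl carbon; no measured step mirrors this. Going by the values given here, the one step in hand, a 3.0-fold higher number from compound 1 to compound 2 (0.47 log units; beyond the scatter), was modest, so a modest step is also expected here, with a slight lean toward a lower number. Compound 3 is therefore estimated at 50 nM in this assay, within a range from 12 nM to 200 nM, which is an expected step of a 1.9-fold lower number from compound 2 to compound 3 (0.28 log units; within the scatter).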

Compound 3, half-maximal inhibitory concentration: 58 nM
The estimate for compound 3 lay 1.2-fold (0.06 log units) below the measured number; the range from low to high includes it.
By their numbers in this assay, from the lowest: compounds 1, 3 and 2 (each within the scatter of the next, the first and the last beyond it).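

In this assay, the 3-phenylpropyl chain on the carbonyl carbon can give way to 1-benzothiophen-2-yl, an aromatic bicycle bound directly with no saturated chain, and the change stays small (a 1.6-fold lower number from compound 2 to compound 3 (0.21 log units; within the scatter)). A saturated chain at this place is therefore not required for a number in this range. Set against the isobutyl group of compound 1, the same group again gives a small change (a 1.8-fold higher number from compound 1 to compound 3 (0.26 log units; within the scatter)), so compound 3 cannot be told apart from either relative, even though those two lie beyond the scatter of each other (a 3.0-fold higher number from compound 1 to compound 2 (0.47 log units; beyond the scatter)). Nothing available explains why these three acyl groups give such similar numbers.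

The compounds shown leave open whether the sulfur of the bicycle matters, which a naphthalen-2-yl or an indol-2-yl group on the same carbonyl carbon would address, and whether a single phenyl ring placed there would serve as well. On these data alone, it also remains open how an amine or a carboxylic acid on the 1-benzothiophen-2-yl group would change the number.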